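From Methoxy to Hydroxy: An Expected Step in Agonist Activity

The source may hold more compounds than are shown below. What is called first, only, known or untested is meant among the compounds shown, and "the series" means these compounds.

Compound 1 `CCCCCCn1c(N)nc2ccccc21`: 3960 nM
Compound 2 `Nc1nc2ccccc2n1Cc1ccccc1`: "not active" (no number reported)
Compound 3 `CCCCCn1c(N)nc2c(OC)cccc21`: 3740 nM

Three compounds sharing one core have been examined in an assay on HEK293 cells for agonist activity at Toll-like receptor 8 (Homo sapiens), read by reporter gene assay; a lower number here means that less compound is needed, a higher number that more compound is needed for the effect. Compound 1 gives 3960 nM. Compound 2 carries a benzyl group in place of the hexyl chain of compound 1. In this assay compound 2 is reported as "not active" (no number reported), so no number stands for it. Compound 3 gives 3740 nM in this assay, and its gap to compound 1 lies within the scatter, so the two cannot be told apart on these numbers. Among the measured compounds shown here, compound 2 stands aside as the one entry without a number.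

The next compound, compound 4 `CCCCCn1c(N)nc2c(O)cccc21`, has not yet been measured. It differs from compound 3 by hydrogen in place of methyl on an oxygen on an aromatic ring. For the measured compounds named here, no pair of measured compounds shows this kind of change, so its effect in this assay is unknown from the data at hand. Going by the values given here, the core and the pentyl chain are kept, and the change is small in what it counts, so the step from compound 3 to compound 4 is expected to be modest, and in which direction cannot be read from the compounds measured so far.

For compound 4 the estimate in this assay is 3000 nM, with a range from 800 nM to 12000 nM, which means an expected step of a 1.2-fold lower number from compound 3 to compound 4 (0.10 log units; within the scatter).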

Compound 4, half-maximal effective concentration: 5010 nM
Estimate against measurement, compound 4: 1.7-fold (0.22 log units) below, within the range that was stated.
By their numbers in this assay, from the lowest: compounds 3, 1 and 4 (each within the scatter of the next).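

In this assay, among the compounds shown here, the exchange of methoxy for hydroxy gives a 1.3-fold higher number from compound 3 to compound 4 (0.13 log units; within the scatter), the first direct reading of this change on the shared core. With the pentyl chain kept, compound 4 with its hydroxy still gives a number, so the methyl on this oxygen is not required for a reported value, and the two compounds cannot be told apart on these numbers. No measurement at hand accounts for this outcome.

For the compounds shown here, the single pair speaks only for this place, this chain and this exchange, so it remains open whether the same change would read the same way with the hexyl chain of compound 1 or the benzyl group of compound 2, the latter reported without a number. Also open, going by these compounds, is what a larger ether such as butoxy, an amine or a chlorine in place of the hydroxy would do, and whether any such group would give a step beyond the scatter.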